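Cytotoxicity notes on the aminopyrimidine triazole series

A few compounds are considered here, and "the series" means these few. Any claim that something is new, unique, unknown or untested is made for them only; others in the source may bear on it.

In an ADME assay on cells (Macrophage) for cytotoxicity, read by resazurin assay, with a stated time of 48 h (a higher number here means that more compound is tolerated, a lower number that less compound is tolerated), compound 1 `Nc1nc(-c2ccc(OCc3cn(Cc4ccccc4)nn3)cc2O)cc(-c2cccc3ccccc23)n1` gives 71300 nM. Compound 2 `Nc1nc(-c2ccc(OCc3cn(Cc4ccccc4)nn3)cc2O)cc(-c2c(F)cccc2Cl)n1` shares the core of compound 1 and was run in this assay, where compound 2 gives "not determined" (no result reported), so compound 2 stands without a number in this series. Compound 3 `Nc1nc(-c2ccccc2)cc(-c2ccc(OCc3cn(Cc4ccccc4)nn3)cc2O)n1` differs from compound 2 in one place: phenyl in place of 2-chloro-6-fluorophenyl on an aromatic carbon. For the measured compounds named here, no step between measured compounds is available for this change, so its size cannot be read from the data. Compound 1 is the only reference in this assay, and the step from compound 2 to compound 3 is expected to lie within the scatter or to move only slightly toward more compound being tolerated, with no direction firmly supported. On that basis compound 3 is estimated to give 80000 nM in this assay, with the expected range running from 30000 nM to 200000 nM.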

Compound 3, half-maximal cytotoxic concentration: 76500 nM
The estimate for compound 3 lay 1.0-fold (0.02 log units) above the measured number, and the stated range covers the measured number.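

In this assay, for the compounds shown here, the change to phenyl in place of naphthalen-1-yl gives a 1.1-fold higher number from compound 1 to compound 3 (0.03 log units; within the scatter) and is the first step that can be read at this position, on the aromatic carbon next to the ring nitrogen. Steps involving compound 2 cannot be read, as it carries no number. No evidence on the cause of this result is available.

The compounds shown carry only carbon aromatic rings at this position, and the one halogenated example, 2-chloro-6-fluorophenyl in compound 2, has no number, so the effect of chlorine or fluorine on the ring remains open. Also open, on these data alone, is how the number would respond to a quite different group on this carbon, such as an amine, a carboxylic acid or a longer alkyl chain.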